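This account rests on a few compounds, and the source may have more. Where it says the series, first, only, none or still open, it means among the compounds named here.

Working notes on a small series of thiol-bearing acrylic acids tested in an assay on isolated protein for inhibition of Calpain-1 catalytic subunit (Sus scrofa), read by FRET; a lower number here means a stronger inhibitor, a higher number a weaker inhibitor. Compound 1 `O=C(O)/C(S)=C/c1ccc(Br)cc1` gives 1500 nM. Compound 2 `O=C(O)/C(S)=C/c1c[nH]c2ccc(Br)cc12` gives 6 nM, and compound 3 `O=C(O)/C(S)=C/c1c[nH]c2ccc(Cl)cc12` gives 250 nM. The difference between the core of compound 1 and the core of compound 2 is not broken down here; the two values simply show compound 1 far weaker. Among the compounds with values here, the single change chloro in place of bromo on an aromatic carbon produced a 42-fold higher number from compound 2 to compound 3 (1.62 log units; beyond the scatter). The same kind of change is now made on the simpler core: compound 4 `O=C(O)/C(S)=C/c1ccc(Cl)cc1` differs from compound 1 by chloro in place of bromo on an aromatic carbon, the place being a six-membered aromatic ring of carbon only, para to a group of 6 heavy atoms, rather than part of a fused system. By analogy, the step expected from compound 1 to compound 4 is an 8.0-fold higher number from compound 1 to compound 4 (0.90 log units; beyond the scatter), resting on a 42-fold higher number from compound 2 to compound 3 (1.62 log units; beyond the scatter), though weaker since the surroundings differ. Compound 4 is estimated at 12000 nM, between 3000 nM and 50000 nM.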

Compound 4, half-maximal inhibitory concentration: 2600 nM
Beside the measured number, compound 4's estimate is 4.6-fold (0.66 log units) above it; measured number outside the range, below it.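

In this assay, the step on the core of compound 1 is a 1.7-fold higher number from compound 1 to compound 4 (0.24 log units; within the scatter), so the large step seen on the core of compound 2 does not carry over in size. The same change therefore reads differently on the two cores: the same change on two cores in this assay, a 42-fold higher number (1.62 log units; beyond the scatter) from compound 2 to compound 3 and a 1.7-fold higher number (0.24 log units; within the scatter) from compound 1 to compound 4, 24-fold (1.38 log units) apart, beyond the scatter of two such steps. This shows that a step measured on one core is a poor guide to the other in this series, but it does not show which part of the cores sets the gap, and two pairs give no rule for any further core.

The compounds shown leave open how a fluoro, a methyl or an amine at the same place would read on either core. They also leave open how a methyl ester in place of the carboxylic acid would read.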